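Methyl on the ring of the morpholine thiosemicarbazone

This account rests on a few compounds, and the source may have more. Where it says the series, first, only, none or still open, it means among the compounds named here.

Measured compounds:
compound 1 `N/C(=N\NC(=S)N1CCCCCC1)c1ccccn1` gives 90%
compound 2 `N/C(=N\NC(=S)N1CCOCC1)c1ccccn1` gives 15%
compound 3 `N/C(=N\NC(=S)N1CCN(c2ccccn2)CC1)c1ccc(F)cn1` gives 73.2%

In a functional assay on A-375 cells (Homo sapiens) for cytotoxicity, read by MTT assay, with a stated time of 72 h, tested at 30 uM (on this read-out lower numbers stand for less inhibition of growth and higher numbers for more inhibition of growth at the one concentration tested), compound 2 stands lowest of the three numbers. Its nearest neighbour is compound 3, which is higher by a margin beyond the scatter; compound 1 lies furthest above it, also beyond the scatter. Compound 4 `Cc1ccnc(/C(N)=N/NC(=S)N2CCOCC2)c1` differs from compound 2 only in that (methyl in place of hydrogen on an aromatic carbon), on an aromatic carbon of a six-membered aromatic ring with one nitrogen, meta to a large group and opposite the ring nitrogen. Among the compounds with values here, no measured pair shows this change, so no step size is known for it. The expectation is a small rise at most, likely within the scatter; the estimated step is a number 7 percentage points higher from compound 2 to compound 4 (within the scatter). Compound 4 is therefore expected to give about 22%, within a range of 5% to 50%.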

Compound 4, percent growth inhibition at one concentration: 87.4%
Compound 4: middle estimate off by 65.4 percentage points, on the low side; the whole stated range lies below it.
By their numbers in this assay, from the lowest: compound 2; then compound 3; then compounds 4 and 1 (each within the scatter of the next).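

With the morpholine kept, the step in this assay is a number 72.4 percentage points higher from compound 2 to compound 4 (beyond the scatter), so the morpholine alone does not fix the low number of compound 2. This aromatic carbon, opposite the ring nitrogen, is therefore a sensitive position, where a single added methyl changes the read-out well beyond the scatter. Nothing available explains the size of this step.

Going by these compounds, whether an ethyl, a methoxy or a chlorine on this same carbon gives a similar number remains open. Also open, on these data alone, is whether methyl here has a comparable effect with the azepane ring of compound 1 in place of the morpholine.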